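The source may hold more compounds than are shown below. What is called first, only, known or untested is meant among the compounds shown, and "the series" means these compounds.

Measured compounds:
compound 1, `COc1ccc(-c2ccc(C(=O)Nc3ccc(Oc4ccnc5[nH]ccc45)cc3)nc2)cc1`, gives > 10000 nM in a functional assay on PC-3 cells (Homo sapiens) for cytotoxicity, read by MTT assay, with a stated time of 72 h; on this read-out higher numbers stand for weaker inhibition and lower numbers for stronger inhibition.
compound 2, `COc1ccc(-c2ccnc(C(=O)Nc3ccc(Oc4ccnc5[nH]ccc45)cc3)c2)cc1`, gives 9620 nM in this assay.
compound 3, `O=C(Nc1ccc(Oc2ccnc3[nH]ccc23)c(F)c1)c1ccc(-c2ccccc2)cn1`, gives 760 nM in this assay.

The value for compound 1 is a limit of this assay and not a number. Of the two numbers actually measured, compound 3 has the lower one; compound 2 sits higher, and the gap between compound 2 and compound 3 lies beyond the usual scatter of this assay.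

Compound 4, `O=C(Nc1ccc(Oc2ccnc3[nH]ccc23)c(F)c1)c1ccc(-c2ccc(F)cc2)cn1`, has not yet been measured. It differs from compound 3 in one place: fluoro in place of hydrogen on an aromatic carbon. Going by the values given here, no pair among the measured compounds differs by just such a change, so there is no measured step to lean on.

A single fluorine added at this place is expected to move the number little: the step from a 1.2-fold lower number from compound 3 to compound 4 (0.07 log units; within the scatter) is estimated to stay within the scatter, in no fixed direction. Compound 4 is therefore expected to give about 650 nM in this assay, estimated between 250 nM and 1800 nM.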

Compound 4, half-maximal inhibitory concentration: 13400 nM
For compound 4 the middle estimate is 21-fold (1.31 log units) below the measured one; the whole stated range lies below it.
By their numbers in this assay, from the lowest: compound 3; then compounds 2 and 4 (each within the scatter of the next).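

In this assay, a single fluoro on an aromatic carbon para to a large group is far from a neutral change: going from phenyl to 4-fluorophenyl gives an 18-fold higher number from compound 3 to compound 4 (1.25 log units; beyond the scatter). Going by these compounds alone, compound 3 and compound 4 differ in this one place only, so the loss of activity can be tied to this one atom, which the earlier compounds could not show, as no two of them differed by a single change. The change also carries compound 4 from the lowest number into the high end of the numbers seen here, the region of the limit: the limit of > 10000 nM in this assay, at which 1 of the 4 values shown sits.

Going by these compounds, whether a chloro, a methyl or an amine on this carbon would act like fluoro remains open. A single pair also cannot show why this small change has so large an effect on the cells.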